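Swapping the Fluorophenyl for a Methoxyphenyl: Expected Tolerability

A few compounds are considered here, and "the series" means these few. Any claim that something is new, unique, unknown or untested is made for them only; others in the source may bear on it.

Compound 1 `Cc1cc(-c2cccc(F)c2)c2ncc(CSCCc3ccccc3)n2c1` has been tested in an ADME assay on HEL cells (Homo sapiens) for cytotoxicity, with a stated time of 3 days; a lower number here means that less compound is tolerated, a higher number that more compound is tolerated. In this assay compound 1 gives 35 ug/mL, the higher of the two numbers seen so far. Compound 2 `Cc1cc(-c2ccc(C#N)cc2)cn2c(CSCCc3ccccc3)cnc12` gives 10.6 ug/mL, a gap that lies beyond the usual scatter. Compound 3 `COc1ccc(-c2cc(C)cn3c(CSCCc4ccccc4)cnc23)cc1` has not yet been measured. It differs from compound 1 at a single place: 4-methoxyphenyl in place of 3-fluorophenyl on an aromatic carbon. Within the data shown here, no measured pair shows this same change, so the expectation rests on compound 1 alone. The step of a 1.2-fold lower number from compound 1 to compound 3 (0.07 log units; within the scatter) is expected to stay within the scatter. Compound 3 is estimated at 30 ug/mL, with a range from 12 ug/mL to 70 ug/mL.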

Compound 3, half-maximal cytotoxic concentration: 19.6 ug/mL
Estimate against measurement, compound 3: 1.5-fold (0.18 log units) above; the measured number falls inside the stated range.
By their numbers in this assay, from the lowest: compounds 2, 3 and 1 (each within the scatter of the next, the first and the last beyond it).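

In this assay, among these compounds, placing 4-methoxyphenyl on this aromatic carbon instead of 3-fluorophenyl gives a 1.8-fold lower number from compound 1 to compound 3 (0.25 log units; within the scatter), the first direct reading of a change at this position. This single step therefore shows no measurable difference between these two groups here, even though the incoming group adds one hydrogen-bond acceptor. No measured evidence bears on why the result came out this way. The step alters both the substituent and its place on the phenyl ring, leaving their separate contributions unresolved. A phenyl ring carrying an amine or a carboxylic acid at this position also remains an open case.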